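The source may hold more compounds than are shown below. What is called first, only, known or untested is meant among the compounds shown, and "the series" means these compounds.

Measured so far:
Compound 1, `CN(C)CCn1cnnc1-c1cc(Oc2ccc(NC(=O)N/N=C/c3ccc(Cl)cc3Cl)cc2F)ccn1`, gives 2330 nM in a functional assay on U-87MG ATCC cells (Homo sapiens) for cytotoxicity, read by MTT assay, with a stated time of 72 h; a lower number here means a stronger inhibitor, a higher number a weaker inhibitor.
Compound 2, `CN(C)CCn1cnnc1-c1cc(Oc2ccc(NC(=O)N/N=C/c3c(Cl)cccc3Cl)cc2F)ccn1`, reaches only a limit of this assay, > 100000 nM.
Compound 3, `CN(C)CCn1cnnc1-c1cc(Oc2ccc(NC(=O)N/N=C/c3cccc(Cl)c3Cl)cc2F)ccn1`, gives 13200 nM in this assay.

Compound 3 stands at the higher of the two numbers measured; its nearest neighbour is compound 1, and the step is a 5.7-fold higher number from compound 1 to compound 3 (0.75 log units; beyond the scatter). Compound 2 gives no number at all, only (the limit of > 100000 nM in this assay, at which 1 of the 3 values shown sits). The next step leads to compound 4, `CN(C)CCn1cnnc1-c1cc(Oc2ccc(NC(=O)N/N=C/c3ccc(Cl)cc3)cc2F)ccn1`, and the change is 4-chlorophenyl in place of 2,3-dichlorophenyl on a carbon with a double bond to nitrogen. Among the measured compounds shown here, none of the measured steps removes a chlorine while keeping the other; all three shift chlorine around the ring: an at least 42-fold higher number from compound 1 to compound 2 (1.63 log units; beyond the scatter) and an at least 7.5-fold lower number from compound 2 to compound 3 (0.87 log units; beyond the scatter), alongside the step from compound 1 to compound 3 already given. The chlorine that compound 4 keeps is the one also found in the 2,4-dichlorophenyl of compound 1, the compound with the lowest number, so a lower number than compound 3 is expected, though not necessarily as low as compound 1. The expected step is a 3.3-fold lower number from compound 3 to compound 4 (0.52 log units; beyond the scatter). Compound 4 is estimated at 4000 nM, within a range from 1200 nM to 15000 nM.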

Compound 4, half-maximal inhibitory concentration: 1370 nM
Beside the measured number, compound 4's estimate is 2.9-fold (0.47 log units) above it; the range from low to high includes it.
By their numbers in this assay, from the lowest: compounds 4 and 1 (each within the scatter of the next); then compound 3. At a limit, above all of these: compound 2.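

Among the compounds shown here, compound 4 is the first ring here with a single chlorine, and hydrogen in place of chloro on the ring of compound 1 gives a 1.7-fold lower number from compound 1 to compound 4 (0.23 log units; within the scatter), so the second chlorine of the 2,4-dichlorophenyl adds nothing that can be told from the scatter. The 4-chlorophenyl also separates clearly from the other two rings: in place of 2,3-dichlorophenyl it gives a 9.6-fold lower number from compound 3 to compound 4 (0.98 log units; beyond the scatter), and in place of 2,6-dichlorophenyl it gives an at least 72-fold lower number from compound 2 to compound 4 (1.86 log units; beyond the scatter). Compound 2 still stands only as a limit in this assay, not as a number: the limit of > 100000 nM in this assay, at which 1 of the 4 values shown sits.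

Every ring shown still carries chlorine, so it remains open whether any chlorine is needed on this ring. A plain phenyl, or a phenyl with a methoxy group or an amine in place of that chlorine, would bear on this.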